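Diethylamino for hydroxyethoxy on an imidazole-thioether urea

The source may hold more compounds than are shown below. What is called first, only, known or untested is meant among the compounds shown, and "the series" means these compounds.

The measured compounds and their values in an assay on microsomes from liver with sterol O-acyltransferase 1 (Rattus norvegicus) as the target; a lower number here means a stronger inhibitor, a higher number a weaker inhibitor:
compound 1, `CC(C)NC(=O)N(CCCCCSc1nc(-c2ccccc2)c(-c2ccccc2)[nH]1)CCOCCO`: 90 nM
compound 2, `CCCCCCCN(CCCCCSc1nc(-c2ccc(N(C)C)cc2)c(-c2ccc(N(C)C)cc2)[nH]1)C(=O)CC1CCCCC1`: 50 nM
compound 3, `CCOCCOCCN(CCCCCSc1nc(-c2ccc(SC)cc2)c(-c2ccc(SC)cc2)[nH]1)C(=O)NC(C)C`: 280 nM

Among these three numbers compound 1 stands second highest. Compound 2 sits near it, with a value that lies within the usual scatter of such measurements, so no order between the two can be read from the data. Compound 3 gives a clearly higher number than compound 1, beyond the scatter, and is the weaker inhibitor of that pair.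

Compound 4, `CCN(CC)CCN(CCCCCSc1nc(-c2ccccc2)c(-c2ccccc2)[nH]1)C(=O)NC(C)C`, keeps the shared core of compound 1 and changes only the chain on the urea nitrogen: diethylamino in place of 2-hydroxyethoxy on a saturated chain carbon, two bonds along the chain from an amide-type nitrogen. Among the measured compounds shown here, no measured pair in this set isolates that change, so the step from compound 1 to compound 4 cannot be calibrated from a neighbouring comparison. The shared core and the five-carbon thioether linker are unchanged, and the two measured compounds with this core, compound 1 and compound 2, both give numbers in the same region of this assay. The step is therefore expected to be small, toward a somewhat lower number if anything, and most likely not beyond the scatter. Compound 4 is estimated at 60 nM, with a plausible range of 20 nM to 250 nM, corresponding to an expected step of a 1.5-fold lower number from compound 1 to compound 4 (0.18 log units; within the scatter) in this assay.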

Compound 4, half-maximal inhibitory concentration: 660 nM
The estimate for compound 4 lay 11-fold (1.04 log units) below the measured number; measured number outside the range, above it.
By their numbers in this assay, from the lowest: compounds 2 and 1 (each within the scatter of the next); then compound 3; then compound 4.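

In this assay, the chain on the urea nitrogen proves to be a position that matters: with the rest of compound 1 held fixed, diethylamino in place of 2-hydroxyethoxy gives a 7.3-fold higher number from compound 1 to compound 4 (0.87 log units; beyond the scatter), a step beyond the scatter toward a weaker inhibitor. Among the compounds shown here, the earlier compounds held no pair differing in one place, so this is the first direct reading of any single change in the set, and it shows that this exchange, on a saturated chain carbon, two bonds along the chain from an amide-type nitrogen, is not neutral. Nothing available here accounts for the size of this step.

This one pair cannot show whether the higher number comes from losing 2-hydroxyethoxy or from bringing in diethylamino. A methoxy group, a dimethylamino group or a morpholine ring on the same chain carbon would help to separate the two, as would a longer chain carrying the diethylamino group.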